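Compound 4 After a Dichlorophenyl Swap

The compounds below may be only part of what the source reports. "The series", "measured", "known", "first", "only" and "open" are said of these compounds alone.

- compound 1 `COc1cccc(/C=C2\CCC/C(=C\c3ccccc3Br)C2=O)c1OC`: 9700 nM
- compound 2 `COc1cccc(/C=C2\CCC/C(=C\c3cccc(Cl)c3Cl)C2=O)c1OC`: > 20000 nM (a limit)
- compound 3 `COc1cccc(/C=C2\CCC/C(=C\c3cc(Cl)cc(Cl)c3)C2=O)c1OC`: 4300 nM

In a functional assay on MCF7 cells (Homo sapiens) for cytotoxicity, read by MTT assay, with a stated time of 72 h (a higher number here means a weaker inhibitor, a lower number a stronger inhibitor), compound 3 gives 4300 nM, the lowest of the numbers, and the nearest is compound 1 at 9700 nM. Compound 2 reads > 20000 nM, which is a limit of the assay.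

Compound 4 `COc1cc(/C=C2\CCC/C(=C\c3cccc(OC)c3OC)C2=O)ccc1O` brings 4-hydroxy-3-methoxyphenyl in place of 3,5-dichlorophenyl on a double-bonded chain carbon bound to a double-bonded ring carbon.

Three measured swaps at this place bear on it: a 2.3-fold lower number from compound 1 to compound 3 (0.35 log units; beyond the scatter), an at least 2.0-fold higher number from compound 1 to compound 2 (0.31 log units; beyond the scatter) and an at least 4.6-fold lower number from compound 2 to compound 3 (0.66 log units; beyond the scatter). They run both ways, and none involves the entering group, so no step beyond the scatter is expected.

The expected step is a 1.4-fold higher number from compound 3 to compound 4 (0.14 log units; within the scatter).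

For compound 4 the estimated value is 6000 nM, within an expected range of 1800 nM to 20000 nM.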

Compound 4, half-maximal inhibitory concentration: 11600 nM
Compound 4: the middle estimate sits 1.9-fold (0.29 log units) below what was measured; the range from low to high includes it.
By their numbers in this assay, from the lowest: compound 3; then compounds 1 and 4 (each within the scatter of the next). At a limit, above all of these: compound 2.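

In this assay, among these compounds, 4-hydroxy-3-methoxyphenyl, the only group at this place with a hydrogen-bond donor, gives a 2.7-fold higher number from compound 3 to compound 4 (0.43 log units; beyond the scatter), so it does not match 3,5-dichlorophenyl. Against 2-bromophenyl it gives a 1.2-fold higher number from compound 1 to compound 4 (0.08 log units; within the scatter), so these two groups read level. Against 2,3-dichlorophenyl it gives an at least 1.7-fold lower number from compound 2 to compound 4 (0.23 log units; that floor lies within the scatter), so this step settles no order between these two groups. Compound 2 stays a limit: the limit of > 20000 nM in this assay, at which 1 of the 4 values shown sits.

Which part of the entering group carries the step stays open, since its hydroxy and methoxy are not separated here. As far as these compounds go, how an amine or a carboxylic acid would read at this place also stays open.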